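The compounds below may be only part of what the source reports. "The series", "measured", "known", "first", "only" and "open" are said of these compounds alone.

Working notes on the series. In a functional assay on the whole organism with Oryctolagus cuniculus as the target (a higher number here means a weaker inhibitor, a lower number a stronger inhibitor), compound 1 (`CO/C(O)=C1\C(C)=Nc2ccccc2SC1c1cccc([N+](=O)[O-])c1`) gives 1200 nM and compound 2 (`CO/C(O)=C1\C(C)=Nc2ccccc2SC1c1ccccc1`) gives 1700 nM. Going by the values given here, these are the only two values so far, and they lie within the scatter of each other, so compound 1 has no clear rank over compound 2.

The next compound is compound 3 (`CCO/C(O)=C1\C(C)=Nc2ccccc2SC1c1cccc([N+](=O)[O-])c1`), which keeps the core of compound 1 and its nitro group. The structural change is methyl in place of hydrogen on a saturated chain carbon bound to an oxygen on an unsaturated carbon, which amounts to methoxy to ethoxy.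

Among the compounds with values here, the only measured step is a 1.4-fold higher number from compound 1 to compound 2 (0.15 log units; within the scatter). It replaces nitro with hydrogen on an aromatic carbon, so it is a different change at a different place and bears on this question only indirectly. Within the data shown here, no measured step covers methoxy to ethoxy, and the data give no direct guide to its size or direction. With a single small step to go on, no shift beyond the scatter is expected in this assay, and no direction can be favoured with any confidence.

The expected step is a 1.1-fold higher number from compound 1 to compound 3 (0.03 log units; within the scatter). For compound 3 the estimated value is 1300 nM, with an expected range of 550 nM to 3000 nM.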

Compound 3, half-maximal inhibitory concentration: 400 nM
Compound 3: middle estimate off by 3.3-fold (0.51 log units), on the high side, outside the stated range (below it).
By their numbers in this assay, from the lowest: compound 3; then compounds 1 and 2 (each within the scatter of the next).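

In this assay, methoxy to ethoxy gives a 3.0-fold lower number from compound 1 to compound 3 (0.48 log units; beyond the scatter), so a single added methyl on a saturated chain carbon bound to an oxygen on an unsaturated carbon is enough to separate two compounds beyond the scatter. The earlier replacement of nitro with hydrogen, a 1.4-fold higher number from compound 1 to compound 2 (0.15 log units; within the scatter), did not do so, which makes this alkoxy position the first place in the series where a one-place change gives a clear difference. The step is modest and rests on one pair, and no available evidence explains it.

The compounds shown leave open whether the trend continues with a longer chain such as propoxy or butoxy, or with a branched group such as isopropoxy, or whether it stops at ethoxy. They also leave open whether the same methoxy to ethoxy change gives a similar step without the nitro group, on the core of compound 2.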